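Moving a halogen on the sulfonyl-bound ring

The compounds below may be only part of what the source reports. "The series", "measured", "known", "first", "only" and "open" are said of these compounds alone.

Compound 2 `O=S(=O)(Nc1ccc2oc(-c3ccccc3)nc2c1)c1ccccc1Cl` carries a 2-chlorophenyl group on its sulfonyl sulfur. In an assay on cells for inhibition of HSP60/HSP10 (Homo sapiens), with a stated time of 60 min (on this read-out lower numbers stand for stronger inhibition and higher numbers for weaker inhibition), compound 2 gives > 100000 nM, which is a limit of the assay rather than a number. Compound 1 `O=S(=O)(Nc1ccc2oc(-c3ccccc3)nc2c1)c1ccccc1C(F)(F)F` differs by a trifluoromethyl where compound 2 has a chloro; in this assay compound 1 gives > 100000 nM, also a limit. The resulting step that the two limits leave unreadable from compound 1 to compound 2 cannot be read from two limits. Compound 3 `O=S(=O)(Nc1ccc(-c2nc3ccccc3o2)cc1)c1ccccc1Cl` places the sulfonamide on a different ring of the shared core; in this assay compound 3 gives > 100000 nM, again a limit. Thus the limit of > 100000 nM in this assay, at which 3 of the 3 values shown sit, is the only evidence here.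

Compound 4 `O=S(=O)(Nc1ccc2oc(-c3ccccc3)nc2c1)c1cccc(F)c1` introduces the change (3-fluorophenyl in place of 2-chlorophenyl on a sulfonyl sulfur). For the measured compounds named here, no measured step bears directly on a 3-fluorophenyl group, so nothing here points to a gain in this assay. Compound 4 is therefore expected to sit at the same limit, with a step of a number no higher from compound 2 to compound 4 (the limit leaves the size open) that is estimated to be nil. The estimate for compound 4 is 100000 nM, with a range from 30000 nM to 300000 nM.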

Compound 4, half-maximal inhibitory concentration: > 100000 nM
Compound 4 was reported as a limit; the forecaster's own chance of this, stated with the estimate: 85%; the middle value lies on the limit itself.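

Compound 2 and compound 4 are both reported only as limits in this assay, so no size can be read for the step between them. The compounds shown leave open which change to the shared core, if any, would give a measurable value: the limit of > 100000 nM in this assay, at which 4 of the 4 values shown sit.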